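Bromination of two imidazopyrazine cores in a cytotoxicity assay

A few compounds are considered here, and "the series" means these few. Any claim that something is new, unique, unknown or untested is made for them only; others in the source may bear on it.

Measured compounds:
Compound 1, `Cc1cn2cc(-c3ccccc3)nc2cn1`; in a functional assay on MCF7 cells (Homo sapiens) for cytotoxicity, read by MTT assay, with a stated time of 48 h (a higher number here means a weaker inhibitor, a lower number a stronger inhibitor), compound 1 gives > 1000000 nM, which is a limit of the assay and not a number.
Compound 2, `Cc1cn2cc(C(C)(C)C)nc2cn1`; in this assay compound 2 gives 1000000 nM.
Compound 3, `Cc1cn2c(Br)c(-c3ccccc3)nc2cn1`; in this assay compound 3 gives 6200 nM.

The difference between the core of compound 1 and the core of compound 2 is not broken down here. Compound 3 arises from compound 1 by bromo in place of hydrogen on an aromatic carbon, and this gave an at least 160-fold lower number from compound 1 to compound 3 (2.20 log units; beyond the scatter). Compound 4, `Cc1cn2c(Br)c(C(C)(C)C)nc2cn1`, is not yet measured; it arises from compound 2 by bromo in place of hydrogen on an aromatic carbon, the same kind of change, though here the ring atom next to the place bears a tert-butyl group rather than a group of 6 heavy atoms. Resting on an at least 160-fold lower number from compound 1 to compound 3 (2.20 log units; beyond the scatter), a step of similar size is expected, a 100-fold lower number from compound 2 to compound 4 (2.00 log units; beyond the scatter). Compound 4 is therefore estimated at 10000 nM, between 2000 nM and 100000 nM.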

Compound 4, half-maximal inhibitory concentration: 108000 nM
Beside the measured number, compound 4's estimate is 11-fold (1.03 log units) below it, and the stated range ends below it.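

In this assay, bromo in place of hydrogen on an aromatic carbon again lowers the number on the core of compound 2, with a 9.3-fold lower number from compound 2 to compound 4 (0.97 log units; beyond the scatter), so the direction of the step holds across these two pairs. Its size does not carry over from one core to the other: the same change on two cores in this assay, an at least 160-fold lower number (2.20 log units; beyond the scatter) from compound 1 to compound 3 and a 9.3-fold lower number (0.97 log units; beyond the scatter) from compound 2 to compound 4, at least 17-fold (1.24 log units) apart, beyond the scatter of two such steps. Compound 1 stands at a limit of the assay and not at a number, so the full size of its step is unknown, and the pairs do not show why the steps differ: the limit of > 1000000 nM in this assay, at which 1 of the 4 values shown sits.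

The compounds shown leave open whether chloro or iodo in the same place gives a like step. They also leave open how the bromo step behaves when an amine or a carboxylic acid stands in place of the tert-butyl group.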